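Benzamido to Methyl(1-methyl-1H-pyrazol-3-yl)amino: Expected Clearance

The source may report more compounds than this note shows. Statements on the series, on what has been measured and on what is new or still open speak of the compounds shown alone.

Measured compounds:
Compound 1 `O=C(Nc1cnc(NCc2c(F)ccc3c2CCO3)n2cnnc12)c1ccccc1`: 10 mL.min-1.g-1
Compound 2 `CN(C)Cc1ccc2c(c1)CN(c1cnc(NCc3c(F)ccc4c3CCO4)c3cn[nH]c(=O)c13)C2=O`: 32 mL.min-1.g-1
Compound 3 `Cn1nccc1-c1cnc(NCc2c(F)ccc3c2CCO3)c2cn[nH]c(=O)c12`: 14 mL.min-1.g-1

Three compounds have been run in an ADME assay on microsomes from liver (Homo sapiens) for metabolic stability, read by LC-MS, using NADPH, with stated times of 5 min and 30 min, tested at 1 uM; on this read-out lower numbers stand for slow clearance and higher numbers for fast clearance. Compound 1 gives the lowest of the three numbers, at 10 mL.min-1.g-1. Compound 3 lies nearest, with 14 mL.min-1.g-1, a gap that stays within the usual scatter, so no order can be read between these two. Compound 2 lies furthest, at 32 mL.min-1.g-1, a gap that is beyond the scatter.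

Compound 4 `CN(c1ccn(C)n1)c1cnc(NCc2c(F)ccc3c2CCO3)n2cnnc12` has not yet been measured in this assay. It differs from compound 1 in one place: methyl(1-methyl-1H-pyrazol-3-yl)amino in place of benzamido on an aromatic carbon. Going by the values given here, no measured pair shows this exact change, so the expectation rests on the three values above. Compound 3, which carries a methylated pyrazole on a different core, gives 14 mL.min-1.g-1, close to compound 1. Compound 4 is therefore expected to show a step of a 1.5-fold higher number from compound 1 to compound 4 (0.18 log units; within the scatter) that is small, upward if anything, and not clearly beyond the scatter. The estimate for compound 4 is 15 mL.min-1.g-1, with a range from 7 mL.min-1.g-1 to 35 mL.min-1.g-1.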

Compound 4, intrinsic clearance in microsomes: 11 mL.min-1.g-1
Compound 4: the middle estimate sits 1.4-fold (0.13 log units) above what was measured; the measured number falls inside the stated range.
By their numbers in this assay, from the lowest: compounds 1, 4 and 3 (each within the scatter of the next); then compound 2.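

In this assay, methyl(1-methyl-1H-pyrazol-3-yl)amino in place of benzamido on this aromatic carbon gives a 1.1-fold higher number from compound 1 to compound 4 (0.04 log units; within the scatter) and provides the only comparison shown that differs in this one place. The position thus accepts a marked change of group without a step beyond the scatter: one six-membered aromatic ring of carbon only and 1 hydrogen-bond donor leave, while one five-membered aromatic ring with 2 hetero atoms and 0 hydrogen-bond donors enter. Nothing measured here explains this result.

The compounds shown leave open whether a simple amine or a carboxylic acid on this aromatic carbon would also stay within the scatter of compound 1. They also leave open whether the methyl on the linking nitrogen of the entering group has any bearing on the result.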